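The source may report more compounds than this note shows. Statements on the series, on what has been measured and on what is new or still open speak of the compounds shown alone.

Within the data shown here, the two compounds measured so far share one core and differ only in the group on the carbonyl carbon. Compound 1 `O=C(C1CCC1)N1CC2CC(C1)N2` carries a cyclobutyl there, and in an assay on SH-EP1 cells for agonist activity at Neuronal acetylcholine receptor; alpha4/beta2 (Homo sapiens), read by FLIPR and calcium flux (on this read-out higher numbers stand for an effect only at larger amounts of compound and lower numbers for an effect already at smaller amounts), compound 1 gives 11000 nM. Compound 2 `O=C(CC1C=CCC1)N1CC2CC(C1)N2` carries a larger group, and in this assay compound 2 gives 37000 nM. Of these two numbers compound 1 has the lower one, and the gap to compound 2 lies beyond the scatter of repeated measurements.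

Compound 3 `C[C@H]1C[C@H]1C(=O)N1CC2CC(C1)N2` has not yet been measured in this assay. The change from compound 1 to compound 3 is 2-methylcyclopropyl in place of cyclobutyl on a carbonyl carbon. The two compounds hold the same atoms, joined differently; the four-membered ring of carbon only gives way to a three-membered one bearing a methyl with two defined stereocentres.

Among the measured compounds shown here, no step between two measured compounds matches this change, so there is no direct guide to its size. Compound 3 is expected to sit near compound 1, with a step of a 1.1-fold higher number from compound 1 to compound 3 (0.04 log units; within the scatter) that may not exceed the scatter. The estimate for compound 3 in this assay is 12000 nM, within the range 4000 nM to 40000 nM.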

Compound 3, half-maximal effective concentration: 5800 nM
Estimate against measurement, compound 3: 2.1-fold (0.32 log units) above; the measured number falls inside the stated range.
By their numbers in this assay, from the lowest: compounds 3 and 1 (each within the scatter of the next); then compound 2.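

Among these compounds, the step of a 1.9-fold lower number from compound 1 to compound 3 (0.28 log units; within the scatter) in this assay is the first look at what happens at this place when the group keeps its heavy-atom count and only the way its atoms are joined differs. The earlier pair showed that a larger group on the carbonyl carbon can move the number beyond the scatter, whereas this pair shows that cyclobutyl and 2-methylcyclopropyl, with a four-membered and a three-membered ring of carbon only, cannot be told apart on this read-out. The numbers alone therefore show that this place accepts the ring exchange without a clear shift, and nothing available explains why the two groups read alike here.

On these data alone, it remains open whether the two defined stereocentres of 2-methylcyclopropyl matter, since only one arrangement appears here, and how a plain cyclopropyl would read on the same carbonyl carbon. Also open, as far as these compounds go, is whether a phenyl ring, an amine or a longer carbon chain at this place would bring the number clearly below those of compound 1 and compound 3.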